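From compound 2 to compound 4: one group exchanged

The source may hold more compounds than are shown below. What is called first, only, known or untested is meant among the compounds shown, and "the series" means these compounds.

Compound 1 `O=C(Nc1cc2ncncc2cc1OCc1ccc(Cl)cc1)Nc1cccc2ccccc12` gives 7700 nM
Compound 2 `O=C(Nc1ccc(Cl)c(Cl)c1)Nc1cc2ncncc2cc1OCc1cccc(F)c1` gives 2000 nM
Compound 3 `O=C(Nc1cccc(Cl)c1)Nc1cc2ncncc2cc1OCc1ccccc1` gives 6400 nM

These numbers come from a functional assay on GBM3 cells (Homo sapiens) for antiproliferative activity, read by WST assay, with a stated time of 72 h; on this read-out lower numbers stand for stronger inhibition and higher numbers for weaker inhibition. Compound 2 has the lowest number of the three, and its gaps to compound 1 and to compound 3 both lie beyond the scatter. Compound 4 `O=C(Nc1ccccc1F)Nc1cc2ncncc2cc1OCc1cccc(F)c1` has not been measured yet. It carries 2-fluorophenyl in place of 3,4-dichlorophenyl on an amide-type nitrogen, and the rest of compound 2 stays as it is.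

For the measured compounds named here, no two measured compounds differ in one place only, so no measured step guides this change directly. The nearest evidence is compound 3 at 6400 nM and compound 1 at 7700 nM, which carry other groups on that nitrogen, though both also differ elsewhere. In this assay the expected move is toward weaker inhibition, beyond the scatter, with an estimated size of a 2.8-fold higher number from compound 2 to compound 4 (0.44 log units; beyond the scatter) as the likely outcome. The estimate for compound 4 is 5500 nM within an expected range of 2200 nM to 14000 nM on this read-out.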

Compound 4, half-maximal inhibitory concentration: 8100 nM
The estimate for compound 4 lay 1.5-fold (0.17 log units) below the measured number; measured number inside the range.
By their numbers in this assay, from the lowest: compound 2; then compounds 3, 1 and 4 (each within the scatter of the next).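

For the compounds shown here, compound 2 and compound 4 differ only in the group on the amide-type nitrogen, so this is the first change here that can be read at a single place. In this assay, 2-fluorophenyl in place of 3,4-dichlorophenyl gives a 4.1-fold higher number from compound 2 to compound 4 (0.61 log units; beyond the scatter), a modest step toward weaker inhibition, which shows that the result responds to the group at this position when the rest of compound 2 stays fixed. No measurement shown here explains this step.

A single exchange cannot separate the effect of losing the chlorine atoms from that of adding the fluorine, or show how much their positions on the ring matter. It also leaves open how a plain phenyl, a methoxyphenyl or a pyridyl ring on this nitrogen would compare with 3,4-dichlorophenyl.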